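Cyclopropyl benzoic acid series: aza replacement of the acid ring

The source may report more compounds than this note shows. Statements on the series, on what has been measured and on what is new or still open speak of the compounds shown alone.

Measured so far:
- compound 1, `O=C(O)c1cccc([C@H]2C[C@@H]2c2ccc(OCc3c(-c4c(Cl)cccc4Cl)noc3C3CC3)cc2Cl)c1`: 90 nM
- compound 2, `O=C(O)c1cccc([C@H]2C[C@](OCCO)(c3ccc(OCc4c(-c5c(Cl)cccc5Cl)noc4C4CC4)cc3Cl)C2)c1`: 377 nM

In an assay on HEK293 cells for agonist activity at Bile acid receptor (Homo sapiens) (a lower number here means that less compound is needed, a higher number that more compound is needed for the effect), compound 1 gives 90 nM and compound 2 gives 377 nM; compound 1 therefore has the lower of the two numbers, and the gap to compound 2 lies beyond the usual scatter. Within the data shown here, compound 2 differs from compound 1 in more than one place, so no single-point step is available from these two.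

Compound 3, `O=C(O)c1cncc(C2CC2c2ccc(OCc3c(-c4c(Cl)cccc4Cl)noc3C3CC3)cc2Cl)c1`, is the next single-point change from compound 1: 2-(5-carboxypyridin-3-yl)cyclopropyl in place of 2-(3-carboxyphenyl)cyclopropyl on an aromatic carbon. Among the measured compounds shown here, no measured pair shows what this exchange does. Given that compound 1 gives 90 nM in this assay, the expectation is a modest rise in the number, a 2.2-fold higher number from compound 1 to compound 3 (0.35 log units; beyond the scatter), though a result within the scatter would not be surprising. Compound 3 is estimated at 200 nM in this assay, with a range from 70 nM to 600 nM.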

Compound 3, half-maximal effective concentration: 14 nM
Beside the measured number, compound 3's estimate is 14-fold (1.15 log units) above it; measured number below the stated range.
By their numbers in this assay, from the lowest: compound 3; then compound 1; then compound 2.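

In this assay, the aromatic ring of the acid-bearing group accepts a hetero atom and the number falls: 2-(5-carboxypyridin-3-yl)cyclopropyl in place of 2-(3-carboxyphenyl)cyclopropyl gives a 6.4-fold lower number from compound 1 to compound 3 (0.81 log units; beyond the scatter). Among these compounds, compounds 1 and 2 both carry a ring of carbon only here, so this is the first reading of a ring nitrogen at this place, and the lower number comes with the same heavy-atom count and one more hydrogen-bond acceptor. No measurement on hand accounts for the shift.

Compound 3 is written without the defined stereocentres of compound 1, so the contribution of the ring nitrogen cannot be separated from any contribution of stereochemistry. From the compounds shown here alone, whether the lower number would hold with an amide or a tetrazole in place of the carboxylic acid remains open.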